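Methyl on the Aromatic Carbon in Two Different Cores

The compounds below may be only part of what the source reports. "The series", "measured", "known", "first", "only" and "open" are said of these compounds alone.

Measured so far in a functional assay on the whole organism for agonist activity, with Mus musculus as the target; on this read-out lower numbers stand for an effect already at smaller amounts and higher numbers for an effect only at larger amounts of compound:
- compound 1, `CC(=O)NCC#CCn1ccnc1`, gives a limit of > 100 mg/kg
- compound 2, `CC(=O)NCC#CCn1cncc1C`, gives a limit of > 100 mg/kg
- compound 3, `O=C1OCCN1CC#CCn1ccnc1`, gives 3 mg/kg

Compound 1 and compound 2 both sit at the limit of > 100 mg/kg in this assay, at which 2 of the 3 values shown sit. Between them lies a step that the two limits leave unreadable from compound 1 to compound 2, the change being (methyl in place of hydrogen on an aromatic carbon). Within the data shown here, compound 3 is the only compound with a number; the difference between its core and the core of compound 1 is not broken down here.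

Compound 4, `Cc1cncn1CC#CCN1CCOC1=O`, is compound 3 with methyl in place of hydrogen on an aromatic carbon. This is the same kind of change as from compound 1 to compound 2; the place differs in that the ring atom next to it bears a large group in compound 3 rather than a group of 8 heavy atoms as in compound 1. Since the earlier step gives no readable size, compound 4 is expected to stay close to compound 3, the estimated step being a 1.3-fold higher number from compound 3 to compound 4 (0.12 log units; within the scatter). The estimate for compound 4 is 4 mg/kg, expected between 1.5 mg/kg and 12 mg/kg.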

Compound 4, dose for half-maximal effect: 30 mg/kg
For compound 4 the middle estimate is 7.5-fold (0.88 log units) below the measured one, and the stated range ends below it.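

In this assay, methyl in place of hydrogen on an aromatic carbon gives a 10-fold higher number from compound 3 to compound 4 (1.00 log units; beyond the scatter), so on the core of compound 3 this change has a readable effect, with the number rising beyond the usual scatter. This is a single readable step, and it does not show that the change acts alike on other cores. On the core of compound 1 the same change cannot be read, as compound 1 and compound 2 each give only a limit: the limit of > 100 mg/kg in this assay, at which 2 of the 4 values shown sit.

The compounds shown leave open whether ethyl or a chlorine atom at this place on the core of compound 3 would give a step of like size. They also leave open how the change behaves on a further core where both partners give numbers.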